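The source may report more compounds than this note shows. Statements on the series, on what has been measured and on what is new or still open speak of the compounds shown alone.

The measured compounds, in a functional assay on XF498 cells (Homo sapiens) for cytotoxicity; a lower number here means that less compound is needed, a higher number that more compound is needed for the effect:
Compound 1, `C=CCCCCCCCC#CC#C/C=C\C(C)=O`, reaches only a limit of the assay, > 50 ug/mL.
Compound 2, `CCCCCCCC#CC#C/C=C\C(C)=O`, likewise reaches only a limit of the assay, > 50 ug/mL.
Compound 3, `CCCCCCCC#CC#CC1CC(=O)C=C(C)C1`, gives a reading of 31.3 ug/mL.

Compound 2 therefore stands at the top of the measured range, at the limit of > 50 ug/mL in this assay, at which 2 of the 3 values shown sit, and no number is known for it, only that it lies beyond what the assay reports. Among the compounds with values here, the one step between measured compounds that differ in a single place, a step that the two limits leave unreadable from compound 1 to compound 2, is unreadable, as both ends are limits, so it gives no measure of how this series responds to change.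

The unmeasured compound 4, `CCCCCCCC#CC#C/C=C/C(C)=O`, differs from compound 2 as follows: the two compounds have the same atoms and bonds and differ only in configuration as drawn: 1 of 1 stereo elements differ; a double bond is drawn Z in compound 2 and E in compound 4. No measured step concerns a change of this kind, so nothing shown fixes its size or direction. Given that compound 2 sits at a limit, the expectation is that compound 4 stays near the same region; the step from compound 2 to compound 4 is expected to be a step that the limit leaves unreadable from compound 2 to compound 4. Compound 4 is accordingly estimated at 60 ug/mL, with a range from 25 ug/mL to 150 ug/mL.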

Compound 4, concentration for half-maximal effect: 1.9 ug/mL
Compound 4: the middle estimate sits 32-fold (1.50 log units) above what was measured; measured number outside the range, below it.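

In this assay, within the data shown here, the drawn configuration of the double bond proves to be a decisive feature of this chain, with the change from Z to E giving the first readable step (an at least 26-fold lower number from compound 2 to compound 4 (1.42 log units; beyond the scatter)). Among these compounds, the earlier compounds could not show this, as their one step could not be read. The step can be assigned to the double bond alone because no other part of the structure changes: the fact that compounds 2 and 4 differ only in the configuration as drawn. Its size is only a bound, as compound 2 rests on a limit of the assay: the limit of > 50 ug/mL in this assay, at which 2 of the 4 values shown sit.

Going by these compounds, whether the E double bond has the same effect on the longer, vinyl-bearing chain of compound 1 remains open. On these data alone, it is also open how far the E compound tolerates other changes, such as a carboxylic acid in place of the carbonyl's methyl group.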